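Replacing an acetyl methyl with a larger aromatic amide

The source may hold more compounds than are shown below. What is called first, only, known or untested is meant among the compounds shown, and "the series" means these compounds.

Compound 1 `CC(=O)NCCC1CCN(S(=O)(=O)NC(=O)NC[C@@H]2C[C@@H]3C=C[C@@H]2C3)CC1`: 18%
Compound 2 `COc1ncccc1C(=O)NCCC1CCN(S(=O)(=O)NC(=O)NC[C@@H]2C[C@@H]3CC[C@@H]2C3)CC1`: 35%

In a functional assay on the whole organism (blood) with Rattus norvegicus as the target, with stated times of 24 h and 1 h, at a dose of 5 mg/kg by the intraperitoneal route (on this read-out lower numbers stand for a weaker effect and higher numbers for a stronger effect at the one dose given), compound 1 gives 18%, the lowest of the two numbers, while compound 2 gives 35%, a difference that lies beyond the scatter. Compound 3 `Cn1cc(C(=O)NCCC2CCN(S(=O)(=O)NC(=O)NC[C@@H]3C[C@@H]4C=C[C@@H]3C4)CC2)c(=O)n(C)c1=O` has not yet been measured. It differs from compound 1 by a group of 10 heavy atoms (6 carbon, 2 nitrogen, 2 oxygen; one six-membered aromatic ring with 2 hetero atoms) in place of one carbon atom, on a carbonyl carbon. Going by the values given here, no measured pair covers this exact change, so the direction is uncertain; a moderate rise is expected, a number 12 percentage points higher from compound 1 to compound 3 (beyond the scatter), because compound 2 gives 35% carrying a larger amide in place of the acetyl. Compound 3 is therefore estimated at 30%, with a range from 12% to 50%.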

Compound 3, a percentage reported as activity, at one dose (the size of the read-out at that dose, not a potency): 23%
Beside the measured number, compound 3's estimate is 7 percentage points above it; the range from low to high includes it.
By their numbers in this assay, from the lowest: compounds 1 and 3 (each within the scatter of the next); then compound 2.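

In this assay the methyl on the carbonyl carbon gives way to a group of 10 heavy atoms, with one six-membered aromatic ring with 2 hetero atoms, and the outcome is a number 5 percentage points higher from compound 1 to compound 3 (within the scatter) in this read-out. At this one dose the two compounds cannot be told apart, so this position accepts a far bigger group, with 4 hydrogen-bond acceptors, without a clear difference. Nothing measured here explains this result.

Going by these compounds, a plain phenyl ring or a simple ethyl group on this carbonyl carbon remains open. So does the behaviour of compound 1 and compound 3 at other doses.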